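From 2-fluorophenyl to 2,4-difluorophenyl

This account rests on a few compounds, and the source may have more. Where it says the series, first, only, none or still open, it means among the compounds named here.

Measured in a functional assay on A549 cells (Homo sapiens) for antiproliferative activity, read by MTT assay; a higher number here means a weaker inhibitor, a lower number a stronger inhibitor:
Compound 1 `Cn1c(=O)c(=O)n(C2CCCC2)c2nc(N/N=C/c3ccc(Cl)cc3)ncc21`: 6890 nM
Compound 2 `Cn1c(=O)c(=O)n(C2CCCC2)c2nc(N/N=C/c3ccccc3F)ncc21`: 31200 nM

Of these two, compound 2 has the higher number, 31200 nM, and so is the weaker inhibitor. Compound 3 `Cn1c(=O)c(=O)n(C2CCCC2)c2nc(N/N=C/c3ccc(F)cc3F)ncc21` turns its 2-fluorophenyl into 2,4-difluorophenyl, with fluoro in place of hydrogen on an aromatic carbon. Going by the values given here, only one measured step bears on this, and only indirectly: a 4.5-fold higher number from compound 1 to compound 2 (0.66 log units; beyond the scatter), a modest rise on going from 4-chlorophenyl to 2-fluorophenyl. Among the compounds with values here, no measured pair isolates the new fluoro. Still, compound 3 regains a halogen para to the large group, as in compound 1, so a small move toward a lower number in this assay is expected, possibly not beyond the scatter. The estimated step is a 1.8-fold lower number from compound 2 to compound 3 (0.26 log units; within the scatter). The estimate for compound 3 is 17000 nM, within a range of 7000 nM to 40000 nM.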

Compound 3, half-maximal inhibitory concentration: 18300 nM
Compound 3: the middle estimate sits 1.1-fold (0.03 log units) below what was measured; the measured number falls inside the stated range.
By their numbers in this assay, from the lowest: compound 1; then compounds 3 and 2 (each within the scatter of the next).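

In this assay, fluoro in place of hydrogen on this aromatic carbon, para to a large group, gives a 1.7-fold lower number from compound 2 to compound 3 (0.23 log units; within the scatter), so on a ring already holding a fluoro group this change shows no effect that can be told apart from the scatter. The halogen at this place does not by itself recover the number of compound 1: the step with 2,4-difluorophenyl in place of 4-chlorophenyl is a 2.7-fold higher number from compound 1 to compound 3 (0.42 log units; beyond the scatter). No measurement shown here offers an explanation for either step.

The compounds shown leave open whether the remaining gap to compound 1 follows from the 2-fluoro group, from fluoro rather than chloro on this carbon, or from both together. Going by these compounds, a 4-fluorophenyl group would separate these, and what an amine or a methoxy group on this same carbon would give in this assay also stays open.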